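The compounds below may be only part of what the source reports. "The series", "measured", "known", "first", "only" and "open" are said of these compounds alone.

Measured in a functional assay on the whole organism for antagonist activity, with Mus musculus as the target; a lower number here means that less compound is needed, a higher number that more compound is needed for the effect:
Compound 1 `CC(=O)N(C)CC#CCN1CCCC1`: > 10 mg/kg
Compound 2 `CC(=O)N(C)CC#CCn1ccnc1`: > 100 mg/kg

Compound 1 stands only at a limit, > 10 mg/kg, with no number behind it. Compound 2 is also reported only as a limit, > 100 mg/kg. Compound 3 `CN(C)C(=O)N(C)CC#CCN1CCCC1` keeps the core of compound 1 and carries dimethylamino in place of methyl on a carbonyl carbon. Within the data shown here, no measured step bears on this change, so the expectation in this assay is weakly held, leaning towards a higher dose. The expected step is a step that the limit leaves unreadable from compound 1 to compound 3. For compound 3 the estimated dose is 30 mg/kg, with an expected range of 8 mg/kg to 100 mg/kg.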

Compound 3, dose for half-maximal effect: > 10 mg/kg
Compound 3: only a limit was reported; the forecaster's own chance of this, stated with the estimate: 60%; the middle value lies beyond the limit too.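

Compound 1 and compound 3 give no readable step, as each is reported only as a limit: the limit of > 10 mg/kg in this assay, at which 2 of the 3 values shown sit.

The compounds shown leave open what dose either needs, and whether dimethylamino in place of methyl on a carbonyl carbon shifts it.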